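Putting a carbonyl group on the hydroxy of compound 2

The source may report more compounds than this note shows. Statements on the series, on what has been measured and on what is new or still open speak of the compounds shown alone.

For the measured compounds named here, in an ADME assay on cells (Hepatocyte, Homo sapiens) for metabolic stability, with a stated time of 30 min (a lower number here means that less of the compound is left, a higher number that more of the compound is left), compound 2 (`O=c1cc(N2CCN(CC3CCC(O)CC3)CC2)sc2c([N+](=O)[O-])cc(C(F)(F)F)cc12`) gives 72.7% and holds the higher of the two numbers so far, while compound 1 (`O=C(OC1CCC(CN2CCN(c3cc(=O)c4cc(C(F)(F)F)cc([N+](=O)[O-])c4s3)CC2)CC1)c1ccc(C(F)(F)F)cc1`) gives 5.2% as the lower one. Compound 3 (`O=C(OC1CCC(CN2CCN(c3cc(=O)c4cc(C(F)(F)F)cc([N+](=O)[O-])c4s3)CC2)CC1)c1cccs1`) carries (thiophen-2-yl)carbonyl in place of hydrogen on an oxygen on a saturated carbon. Going by the values given here, the one measured step that bears on this, a number 67.5 percentage points higher from compound 1 to compound 2 (beyond the scatter) on losing (4-(trifluoromethyl)phenyl)carbonyl from that oxygen, was large and beyond the scatter. Read backwards, it leads to the expectation of a large fall, estimated as a number 62.7 percentage points lower from compound 2 to compound 3 (beyond the scatter) here, though no measurement yet compares the two groups. In this assay the estimate for compound 3 is 10% with 2% to 30% as its expected range.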

Compound 3, percent of the compound remaining: 2.2%
Compound 3: the middle estimate sits 7.8 percentage points above what was measured; the measured number falls inside the stated range.
By their numbers in this assay, from the lowest: compounds 3 and 1 (each within the scatter of the next); then compound 2.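

In this assay, the large fall on capping the hydroxy is not tied to one group: (thiophen-2-yl)carbonyl also gives a number 70.5 percentage points lower from compound 2 to compound 3 (beyond the scatter). Exchanging the ring on the carbonyl makes no readable difference, with a number 3 percentage points lower from compound 1 to compound 3 (within the scatter), so in these three compounds the low numbers go with a ring-bearing carbonyl on that oxygen, whichever of the two rings it carries. Nothing available explains why the compound disappears faster with either group. From the compounds shown here alone, whether an acetyl group would bring the same fall remains open. So does whether a methyl ether on that oxygen, which has no carbonyl, would do so.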